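Efficacy at the receptor: from a trifluoromethyl to a 4-chlorobenzyl

This account rests on a few compounds, and the source may have more. Where it says the series, first, only, none or still open, it means among the compounds named here.

Measured so far:
compound 1, `CC(C)(C)[C@H](C(=O)Nc1ncc(F)s1)c1ccc(Cl)cc1`, 92%
compound 2, `CC(C)(C)[C@H](C(=O)Nc1ncc(C(F)(F)F)s1)c1ccc(Cl)cc1`, 95%

In a functional assay on CHO cells for agonist activity at Free fatty acid receptor 2 (Homo sapiens), read by cAMP accumulation (on this read-out higher numbers stand for larger maximal responses and lower numbers for smaller maximal responses), compound 2 gives the higher of the two numbers, and compound 1 comes nearest with a number 3 percentage points higher from compound 1 to compound 2 (within the scatter). The step from compound 2 to compound 3, `CC(C)(C)[C@H](C(=O)Nc1ncc(Cc2ccc(Cl)cc2)s1)c1ccc(Cl)cc1`, exchanges (4-chlorobenzyl in place of trifluoromethyl on an aromatic carbon). Among the compounds with values here, the only measured step is the one from compound 1 to compound 2, which stayed within the scatter, and it concerned a far smaller group than the one that enters here. Within the data shown here, the data give no step of comparable size, so compound 3 is expected to show a number 10 percentage points lower from compound 2 to compound 3 (within the scatter), an estimate of 85%, ranging from 55% to 105%.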

Compound 3, largest response reached (reported as efficacy), in percent of the reference or control that the assay uses: 100%
Compound 3: middle estimate off by 15 percentage points, on the low side; low and high end bracket the measured number.
By their numbers in this assay, from the lowest: compounds 1, 2 and 3 (each within the scatter of the next).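

At the aromatic carbon next to the ring sulfur, the 4-chlorobenzyl brings a six-membered aromatic ring of carbon only, yet this assay shows a number 5 percentage points higher from compound 2 to compound 3 (within the scatter) and a number 8 percentage points higher from compound 1 to compound 3 (within the scatter). Among these compounds, the position therefore accepts a larger, ring-bearing group as well as fluoro and trifluoromethyl, with every step within the scatter. No evidence on the reason for this is at hand.

As far as these compounds go, whether an amine or a carboxylic acid at this carbon would give a similar maximal response remains open. So does the effect of a longer chain between the two rings.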